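Swapping the benzyl substituent on a cyclic sulfamide core

The source may hold more compounds than are shown below. What is called first, only, known or untested is meant among the compounds shown, and "the series" means these compounds.

Within the data shown here, compound 2 `COc1ccc(CN2c3ccccc3C(OCc3ccccc3)=NS2(=O)=O)cc1` is one of two compounds measured so far in a functional assay on MRC5 cells (Homo sapiens); a higher number here means that more compound is tolerated, a lower number that less compound is tolerated. In this assay compound 2 gives 61000 nM, the higher of the two numbers, while compound 1 `O=C1c2ccccc2N(Cc2ccc([N+](=O)[O-])cc2)S(=O)(=O)N1Cc1ccc([N+](=O)[O-])cc1` gives 53000 nM; the two values lie within the scatter of each other, so no order can be read from them. Compound 3 `O=S1(=O)N=C(OCc2ccccc2)c2ccccc2N1Cc1ccc(Cl)c(Cl)c1` has not yet been measured. It differs from compound 2 in one place: 3,4-dichlorophenyl in place of 4-methoxyphenyl on a saturated chain carbon bound to a sulfonamide nitrogen in a ring. Among the measured compounds shown here, no measured pair in this set shows what such a change does in this assay, so the expectation rests on the standing of compound 2 alone. A step of modest size, if any, is expected from compound 2 to compound 3 in this assay, estimated as a 1.4-fold lower number from compound 2 to compound 3 (0.13 log units; within the scatter), which is not clearly beyond the scatter. For compound 3 the estimated value in this assay is 45000 nM, with the expected range running from 20000 nM up to 95000 nM.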

Compound 3, half-maximal cytotoxic concentration: 56000 nM
Estimate against measurement, compound 3: 1.2-fold (0.09 log units) below, and the stated range covers the measured number.
By their numbers in this assay, from the lowest: compounds 1, 3 and 2 (each within the scatter of the next).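

In this assay, among these compounds, 3,4-dichlorophenyl in place of 4-methoxyphenyl on a saturated chain carbon bound to a sulfonamide nitrogen in a ring gives a 1.1-fold lower number from compound 2 to compound 3 (0.04 log units; within the scatter), the first step in this set between compounds that differ in one place. The read-out therefore does not separate these two groups at this position, even though 4-methoxyphenyl carries a hydrogen-bond acceptor and 3,4-dichlorophenyl carries none. Nothing available here offers an explanation for this result.

Going by these compounds, whether the read-out stays just as unmoved with an amine or a carboxylic acid on the phenyl ring, or with a longer chain in place of the benzyl link, remains open. The benzyloxy group is the same in compound 2 and compound 3, so its part in this assay is also unknown.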